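The source may hold more compounds than are shown below. What is called first, only, known or untested is meant among the compounds shown, and "the series" means these compounds.

Compound 1, `NS(=O)(=O)c1ccc(N/C(S)=N\c2ccnc3cc(C(F)(F)F)ccc23)cc1`: 52200 nM
Compound 2, `N=C(N)NS(=O)(=O)c1ccc(N/C(S)=N\c2ccnc3cc(C(F)(F)F)ccc23)cc1`: 33500 nM
Compound 3, `O=S(=O)(Nc1ccccn1)c1ccc(N/C(S)=N\c2ccnc3cc(C(F)(F)F)ccc23)cc1`: 28000 nM

All three were measured in a functional assay on HepG2 cells (Homo sapiens) for antiproliferative activity, read by sulforhodamine B assay, with a stated time of 48 h; a lower number here means a stronger inhibitor, a higher number a weaker inhibitor. Compound 3 has the lowest of the three numbers, but its distance to compound 2 and to compound 1 lies within the usual scatter of repeated measurements, so the three cannot be told apart with confidence. Compound 4, `Cc1ccnc(NS(=O)(=O)c2ccc(N/C(S)=N\c3ccnc4cc(C(F)(F)F)ccc34)cc2)n1`, has not yet been measured. It differs from compound 3 in one place: 4-methylpyrimidin-2-yl in place of pyridin-2-yl on a sulfonamide nitrogen. All three earlier steps also changed what sits on the sulfonamide nitrogen: a 1.6-fold lower number from compound 1 to compound 2 (0.19 log units; within the scatter), a 1.9-fold lower number from compound 1 to compound 3 (0.27 log units; within the scatter) and a 1.2-fold lower number from compound 2 to compound 3 (0.08 log units; within the scatter). None of them moved the number beyond the scatter. The change to compound 4 is of the same kind, a swap of the group on that nitrogen, so no step beyond the scatter is expected in this assay in either direction. For compound 4 the expected value is 25000 nM, with a range from 10000 nM to 65000 nM. This estimate means the step of a 1.1-fold lower number from compound 3 to compound 4 (0.05 log units; within the scatter), which is expected to stay small.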

Compound 4, half-maximal inhibitory concentration: "not active" (no number reported)
The entry for compound 4 holds no number; the estimate stays without a comparison.
By their numbers in this assay, from the lowest: compounds 3, 2 and 1 (each within the scatter of the next).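

In this assay, among these compounds, compound 4 is reported as "not active" without a number, so no step from compound 3 to compound 4 can be read. The compounds shown leave open how large the difference between these two compounds is. Nothing shown explains this result.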